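Methoxy to hydroxy on the limit-bound compound 3

A few compounds are considered here, and "the series" means these few. Any claim that something is new, unique, unknown or untested is made for them only; others in the source may bear on it.

In a functional assay on DU-145 cells (Homo sapiens) for cytotoxicity, read by MTT assay, with a stated time of 72 h (a lower number here means a stronger inhibitor, a higher number a weaker inhibitor), compound 1 (`COc1ccc(/C=C/c2cc(C)no2)cc1OC`) gives > 100000 nM, which is a limit and not a number. Compound 3 (`COc1ccc(/C=C/c2cc(C)no2)cc1`) gives > 100000 nM, again only a limit. Compound 3 therefore stands at the limit of > 100000 nM in this assay, at which 2 of the 3 values shown sit. For the measured compounds named here, compound 2 (`Cc1cc(/C=C/c2ccc(O)c(O)c2)on1`), which carries hydroxy groups on the aromatic ring, gives 10500 nM, the only true number so far.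

Compound 4 (`Cc1cc(/C=C/c2ccc(O)cc2)on1`) is derived from compound 3 by one change: hydrogen in place of methyl on an oxygen on an aromatic ring. In words, this is hydrogen in place of methyl on an oxygen on an aromatic ring, or methoxy to hydroxy.

Going by the values given here, the one measured step, a step that the two limits leave unreadable from compound 1 to compound 3, replaces methoxy with hydrogen and gives no size to carry over. Among the compounds with values here, the expectation therefore rests on compound 2 at 10500 nM, the sole hydroxy-bearing compound with a number. Compound 4 is expected to read as a stronger inhibitor than the limit of compound 3, but not clearly stronger than compound 2, and it may still end at the limit. The expected change is an at least 2.8-fold lower number from compound 3 to compound 4 (0.45 log units; beyond the scatter), towards stronger inhibition, and its size is only an estimate. For compound 4 the estimated value is 35000 nM, with an expected range from 10000 nM to 100000 nM.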

Compound 4, half-maximal inhibitory concentration: 67200 nM
Beside the measured number, compound 4's estimate is 1.9-fold (0.28 log units) below it; the range from low to high includes it.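

In this assay, methoxy to hydroxy on the aromatic ring gives an at least 1.4-fold lower number from compound 3 to compound 4 (0.17 log units; that floor lies within the scatter), so this change can be read only as a floor and cannot be placed beyond the scatter. The reading for compound 3, > 100000 nM, is a limit and not a number, and the true size of the step stays hidden behind it: the limit of > 100000 nM in this assay, at which 2 of the 4 values shown sit.

Hydrogen in place of hydroxy on an aromatic carbon gives a 6.4-fold higher number from compound 2 to compound 4 (0.81 log units; beyond the scatter), the only step shown between two true numbers, and it places the second hydroxy of compound 2 beyond the scatter in this assay.

Going by these compounds, the step between the two methoxy compounds cannot be read, so the contribution of the second methoxy stays unknown, and the size of methoxy to hydroxy remains open on its upper side. Also open, on these data alone, is how an amine or a carboxylic acid in place of the hydroxy of compound 4 would read, and whether an ethyl or longer chain on that oxygen would stay at the limit seen for compound 3.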